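The source may hold more compounds than are shown below. What is called first, only, known or untested is meant among the compounds shown, and "the series" means these compounds.

In a functional assay on K562 cells (Homo sapiens) for cytotoxicity, read by sulforhodamine B assay (on this read-out higher numbers stand for weaker inhibition of growth and lower numbers for stronger inhibition of growth), compound 1 `CC1=CC[C@@H]([C@@](C)(O)CCCC(C)(C)NC(=S)N/N=C\c2ccccc2[N+](=O)[O-])CC1` gives 190 nM and compound 2 `CC1=CC[C@@H]([C@@](C)(O)CCCC(C)(C)NC(=S)N/N=C\c2ccccc2Cl)CC1` gives 150 nM in the same test. Going by the values given here, these two numbers lie within the scatter of each other, so compound 2 stands level with compound 1, its only neighbour so far. Compound 3 `CC1=CC[C@@H]([C@@](C)(O)CCCC(C)(C)NC(=S)N/N=C\c2ccc(Cl)cc2)CC1` has the same atoms as compound 2, joined differently: 4-chlorophenyl in place of 2-chlorophenyl on a carbon with a double bond to nitrogen with 4-chlorophenyl in place of 2-chlorophenyl on a carbon with a double bond to nitrogen. Among the compounds with values here, the only measured step is a 1.3-fold lower number from compound 1 to compound 2 (0.10 log units; within the scatter) with chloro in place of nitro on an aromatic carbon. Within the data shown here, it bears only loosely on this change, since no measured pair tests 4-chlorophenyl. With so little evidence, no step beyond the scatter is expected in this assay and the expected step is a 1.1-fold higher number from compound 2 to compound 3 (0.03 log units; within the scatter) for now. For compound 3 the estimated value is 160 nM with an expected range from 70 nM to 360 nM in this read-out.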

Compound 3, concentration for 50% growth inhibition: 40 nM
Compound 3: the middle estimate sits 4.0-fold (0.60 log units) above what was measured; the whole stated range lies above it.
By their numbers in this assay, from the lowest: compound 3; then compounds 2 and 1 (each within the scatter of the next).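

In this assay, the earlier exchange of nitro for chloro had left the number within the scatter, but moving the chlorine gives a 3.8-fold lower number from compound 2 to compound 3 (0.57 log units; beyond the scatter), so 4-chlorophenyl and 2-chlorophenyl are not interchangeable on the carbon with a double bond to nitrogen even though they have the same atoms. The same 4-chlorophenyl group in place of 2-nitrophenyl gives a 4.8-fold lower number from compound 1 to compound 3 (0.68 log units; beyond the scatter), and so the arrangement on the aromatic ring matters here more than the earlier exchange of groups showed. No measured evidence accounts for this difference.

The compounds shown leave open whether the lower number belongs to chloro itself or would also appear with another group in its place, such as methoxy or a dimethylamino group. They also leave open whether an unsubstituted phenyl would stand with compound 3 or with compound 2.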